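Compound 1 to compound 4: adding trifluoromethyl

The compounds below may be only part of what the source reports. "The series", "measured", "known", "first", "only" and "open" are said of these compounds alone.

Compound 1 `Cc1nn(-c2ccccc2)c2nc(-c3ccccc3)c(C#N)c(-c3ccccc3O)c12`: > 23000 nM (a limit)
Compound 2 `CCc1ccc(-c2nc3c(c(C)nn3-c3ccccc3)c(-c3ccccc3C)c2C#N)cc1`: > 20000 nM (a limit)
Compound 3 `CCc1ccc(-c2nc3c(c(C)nn3-c3ccccc3)c(-c3ccccc3C(=O)OC)c2C#N)cc1`: > 20000 nM (a limit)

In an ADME assay on BJ cells (Homo sapiens) for cytotoxicity, with a stated time of 72 h (a lower number here means that less compound is needed, a higher number that more compound is needed for the effect), compound 1 gives > 23000 nM, which is a limit and not a number. For the measured compounds named here, no measured compound here has an exact value: the limit of > 20000 nM in this assay, at which 2 of the 3 values shown sit, and (the limit of > 23000 nM in this assay, at which 1 of the 3 values shown sits). Compound 4 `Cc1nn(-c2ccccc2)c2nc(-c3ccc(C(F)(F)F)cc3)c(C#N)c(-c3ccccc3O)c12` has trifluoromethyl in place of hydrogen on an aromatic carbon. Going by the values given here, the only measured step is a step that the two limits leave unreadable from compound 2 to compound 3, and it is a different change, so it offers no size to carry over. A step beyond the usual scatter is therefore not expected, in either direction, and compound 4 may well give only a limit too. The estimated step is a step that the limit leaves unreadable from compound 1 to compound 4. For compound 4 the expected value is 25000 nM, with an expected range from 10000 nM to 50000 nM.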

Compound 4, half-maximal effective concentration: 22900 nM
Estimate against measurement, compound 4: 1.1-fold (0.04 log units) above; measured number inside the range.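

In this assay compound 4 gives 22900 nM, the first exact number among the compounds shown, so the change from phenyl to 4-(trifluoromethyl)phenyl yields a readable value at this position. The step is a number no higher from compound 1 to compound 4 (the limit leaves the size open) and its size stays open, because the value it starts from is only a limit and not a number: the limit of > 23000 nM in this assay, at which 1 of the 4 values shown sits.

The compounds shown leave open how far compound 4 truly lies from compound 1. They also leave open whether an amine or a carboxylic acid in the same place would give an exact number too.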